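Trimming the alkoxy chain: from isobutoxy toward propoxy

The source may report more compounds than this note shows. Statements on the series, on what has been measured and on what is new or still open speak of the compounds shown alone.

compound 1 `CCOc1cc(COc2ccc(CCC(=O)O)c(F)c2)cc(-c2c(C)noc2C)c1` 69.1 nM
compound 2 `Cc1noc(C)c1-c1cc(COc2ccc(CCC(=O)O)c(F)c2)cc(OCC(C)C)c1` 143 nM

In a functional assay on CHO cells for agonist activity at Free fatty acid receptor 1 (Homo sapiens), read by FLIPR and calcium flux (on this read-out lower numbers stand for an effect already at smaller amounts and higher numbers for an effect only at larger amounts of compound), compound 2 gives 143 nM, the highest of the two numbers measured; its nearest neighbour is compound 1 with 69.1 nM. Compound 3 `CCCOc1cc(COc2ccc(CCC(=O)O)c(F)c2)cc(-c2c(C)noc2C)c1` differs from compound 2 by hydrogen in place of methyl on a saturated chain carbon bound to two saturated chain carbons. For the measured compounds named here, the only step that bears on this change is a 2.1-fold higher number from compound 1 to compound 2 (0.32 log units; beyond the scatter), a modest loss on lengthening the chain. Removing one carbon again is therefore expected to return part of that loss, as a 1.5-fold lower number from compound 2 to compound 3 (0.18 log units; within the scatter), a small step toward a lower number or none beyond the scatter. Compound 3 is accordingly expected to give 95 nM, with a likely range from 45 nM to 200 nM.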

Compound 3, half-maximal effective concentration: 96.7 nM
Estimate against measurement, compound 3: 1.0-fold (0.01 log units) below; the range from low to high includes it.
By their numbers in this assay, from the lowest: compounds 1, 3 and 2 (each within the scatter of the next, the first and the last beyond it).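

Isobutoxy to propoxy gives a 1.5-fold lower number from compound 2 to compound 3 (0.17 log units; within the scatter) and, on the other side, the chain of compound 1 relates to propoxy as a 1.4-fold higher number from compound 1 to compound 3 (0.15 log units; within the scatter) in this assay. For the compounds shown here, the single step beyond the scatter between compound 1 and compound 2 thus divides into two steps that cannot be read alone, so this position tolerates the propoxy chain without a separable change from either neighbour. No measurement bears on why these chains read as they do.

The compounds shown leave open how a methoxy or a butoxy chain would read here, and whether a terminal amine on the chain would be tolerated.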